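The compounds below may be only part of what the source reports. "The series", "measured", "known", "first", "only" and "open" are said of these compounds alone.

The series shares the core of compound 1 `O=c1[nH]/c(=C\c2cccc(Oc3ccc(F)cc3)c2)c(=O)[nH]/c1=C\c1cccnc1`, which in a functional assay on NCI-H460 cells (Homo sapiens) for cytotoxicity, read by MTT assay, with a stated time of 72 h (a lower number here means a stronger inhibitor, a higher number a weaker inhibitor), gives only a limit, > 1000 nM. Compound 2 `O=c1[nH]/c(=C\C2CCCCC2)c(=O)[nH]/c1=C\c1cccc(Oc2ccc(F)cc2)c1` likewise returns only a limit in this assay, > 1000 nM. Within the data shown here, the single measured step, a step that the two limits leave unreadable from compound 1 to compound 2, is therefore of unknown size; the limit of > 1000 nM in this assay, at which 2 of the 2 values shown sit, is all that the numbers show. Compound 3 `O=c1[nH]/c(=C\c2cccs2)c(=O)[nH]/c1=C\c1cccc(Oc2ccc(F)cc2)c1` differs from compound 2 by thiophen-2-yl in place of cyclohexyl on a double-bonded chain carbon bound to an aromatic carbon. Among the measured compounds shown here, no measured step bears directly on this change, and the one recorded step between compound 1 and compound 2 gives no readable size, so there is no basis for expecting movement beyond the scatter in either direction. Compound 3 is accordingly expected at 3000 nM, within 800 nM to 20000 nM, with the step that the limit leaves unreadable from compound 2 to compound 3 expected to stay inside the scatter and a limit again the most probable outcome.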

Compound 3, half-maximal inhibitory concentration: > 1000 nM
Compound 3 gave a limit, no number; the forecaster's own chance of this, stated with the estimate: 75%; the middle value lies beyond the limit too.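

In this assay compound 3 gives only a limit, > 1000 nM. The steps among compound 1, compound 2 and compound 3 therefore cannot be read. The compounds shown leave open where each lies beyond the limit and whether any of these groups on the double-bonded chain carbon changes the value.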